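The source may hold more compounds than are shown below. What is called first, only, known or untested is meant among the compounds shown, and "the series" means these compounds.

Working notes on the series.

Compound 1 `O=C(O)c1ccc2cc(N3CCC4(C=C(c5c(-c6c(Cl)cccc6Cl)noc5C5CC5)C4)CC3)ccc2n1` is the reference point here. Among the measured compounds shown here, in an ADME assay on microsomes from liver (Homo sapiens) for metabolic stability (a higher number here means that the compound lasts longer, a lower number that the compound disappears faster), compound 1 gives 0.983 h, the higher of the two numbers measured so far. For the measured compounds named here, compound 2 `O=C(O)c1cc(F)c2nc(N3CCC(/C=C/c4c(-c5c(Cl)cccc5Cl)noc4C4CC4)CC3)sc2c1`, a different scaffold, gives 0.217 h in this assay, a gap to compound 1 that lies beyond the usual scatter; no single-point step connects these two, so their values stand only side by side.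

Compound 3 `O=C(O)c1ccc2cc(N3CCC4(C=C(c5c(-c6c(Cl)cc(F)cc6Cl)noc5C5CC5)C4)CC3)ccc2n1` is not yet measured in this assay. It differs from compound 1 in one place: fluoro in place of hydrogen on an aromatic carbon. In words of the difference, a 2,6-dichlorophenyl becomes a 2,6-dichloro-4-fluorophenyl. Going by the values given here, no measured step of this kind is available, so the expected step from compound 1 to compound 3 is a 1.2-fold higher number from compound 1 to compound 3 (0.09 log units; within the scatter), taken as small and, if anything, upward, yet not clearly beyond the scatter. For compound 3 the half-life in this assay is estimated at 1.2 h, with a range from 0.6 h to 2.5 h, resting on compound 1 at 0.983 h.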

Compound 3, half-life: 1.67 h
For compound 3 the middle estimate is 1.4-fold (0.14 log units) below the measured one; measured number inside the range.
By their numbers in this assay, from the lowest: compound 2; then compounds 1 and 3 (each within the scatter of the next).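

Fluoro in place of hydrogen on an aromatic carbon, para to a large group and meta to two chloro groups, gives the first single-point step in the series: in this assay it reads a 1.7-fold higher number from compound 1 to compound 3 (0.23 log units; within the scatter). This step stays within the scatter, so the 2,6-dichloro-4-fluorophenyl cannot be told apart from the 2,6-dichlorophenyl in this read-out, and the change cannot be called a gain. No measurement that bears on the reason for this step is available.

As far as these compounds go, whether a methoxy or a nitrile on this same aromatic carbon would give a step beyond the scatter remains open. Also open, from the compounds shown here alone, is whether the same fluoro step would read alike on the scaffold of compound 2.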